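Lengthening the acyl chain on an aminophenyl amidine scaffold

The source may report more compounds than this note shows. Statements on the series, on what has been measured and on what is new or still open speak of the compounds shown alone.

Three compounds share a core that carries an aniline ring on a cyclic amidine, with an acyl group on the ring nitrogen. Compound 1 `CCCC(=O)N1CCC(c2cc(Cl)ccc2N)=N1` bears a chloro group on the aromatic ring, compound 2 `CCCC(=O)N1CCC(c2cc(OC)ccc2N)=N1` a methoxy group there, and compound 3 `CC(=O)N1CCC(c2ccccc2N)=N1` has an unsubstituted aromatic ring and the shortest acyl group. In an assay on isolated protein for inhibition of Nitric oxide synthase, inducible (Homo sapiens), with a stated time of 30 min, tested at 1 mM (on this read-out higher numbers stand for more inhibition at the one concentration tested (going by the name of the read-out) and lower numbers for less inhibition), compound 1 gives 0.29%, compound 2 gives 13.1% and compound 3 gives 7.73%. The one step among these that changes a single place is a number 12.8 percentage points higher from compound 1 to compound 2 (beyond the scatter). Compound 3 sits within the usual scatter of both compound 2 and compound 1, so its number cannot be told apart from either.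

Compound 4 `CCCC(=O)N1CCC(c2ccccc2N)=N1` differs from compound 3 by ethyl in place of hydrogen on a saturated chain carbon bound to a carbonyl carbon, so the change is methyl to propyl, acetyl to propylcarbonyl. For the measured compounds named here, no measured pair shows this change: the only step seen concerns the aromatic substituent, not the acyl chain, and so does not bear on it. With nothing pointing in either direction, the expected step of a number 0.3 percentage points higher from compound 3 to compound 4 (within the scatter) in this assay is none beyond the scatter. Compound 4 is therefore estimated at 8%, within a range from 0% to 25%.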

Compound 4, a percentage reported as inhibition, at one concentration (the size of the read-out at that concentration, not a potency): 0.35%
Compound 4: the middle estimate sits 7.7 percentage points above what was measured; the range from low to high includes it.
By their numbers in this assay, from the lowest: compounds 1, 4, 3 and 2 (each within the scatter of the next, the first and the last beyond it).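

In this assay, the change from acetyl to propylcarbonyl on the shared core gives a number 7.4 percentage points lower from compound 3 to compound 4 (within the scatter), so with an unsubstituted aromatic ring this longer acyl group has no effect that can be told from the scatter. Compound 4 also serves as the unsubstituted reference for the aromatic carbon, and the two steps from it differ: taking away methoxy gives a number 12.8 percentage points lower from compound 2 to compound 4 (beyond the scatter), while taking away chloro gives a number 0.1 percentage points higher from compound 1 to compound 4 (within the scatter), so among these three propylcarbonyl compounds only the methoxy compound, compound 2, stands apart, and chloro leaves the number where the unsubstituted ring has it. No measurement shown here offers an explanation for this difference between methoxy and chloro.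

As far as these compounds go, it remains open whether a longer chain on the carbonyl, or an amine or a hydroxyl on the aromatic carbon in place of methoxy, would move the number beyond the scatter. Also open is whether the methoxy step would hold with acetyl in place of propylcarbonyl, and how any of these compounds would behave at other concentrations.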